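This account rests on a few compounds, and the source may have more. Where it says the series, first, only, none or still open, it means among the compounds named here.

Measured compounds:
- compound 1, `COc1cc2ncnc(NNC(=S)NC(=O)c3ccc(F)cc3)c2cc1OC`, gives 15300 nM
- compound 2, `Cc1ccc(C(=O)NC(=S)NNc2ncnc3ccccc23)cc1`, gives 11200 nM
- compound 3, `O=C(NC(=S)NNc1ncnc2ccccc12)c1ccc(Cl)cc1`, gives 6680 nM

All three values come from a functional assay on GLC82 cells (Homo sapiens) for cytotoxicity, read by MTT assay, with a stated time of 72 h; a lower number here means a stronger inhibitor, a higher number a weaker inhibitor. Compound 1 has the highest of the three numbers: compound 2 sits nearest, within the scatter, while compound 3 lies furthest from compound 1, beyond the scatter.

Compound 4, `COc1cc2ncnc(NNC(=S)NC(=O)c3ccccc3OC)c2cc1OC`, is not yet measured. It differs from compound 1 in one place: 2-methoxyphenyl in place of 4-fluorophenyl on a carbonyl carbon.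

Among the measured compounds shown here, only one measured step changes a group on the same aromatic ring: a 1.7-fold lower number from compound 2 to compound 3 (0.22 log units; within the scatter). That step was within the scatter. For the measured compounds named here, no measured step trades a 4-fluorophenyl for a 2-methoxyphenyl, so the expectation for compound 4 rests on that single small step and on compound 1 itself. Because a 1.7-fold lower number from compound 2 to compound 3 (0.22 log units; within the scatter) stayed within the scatter, a change on this ring is expected to move the number little. Compound 4 is therefore estimated at 13000 nM, with a range from 5000 nM to 35000 nM, which means an expected step of a 1.2-fold lower number from compound 1 to compound 4 (0.07 log units; within the scatter).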

Compound 4, half-maximal inhibitory concentration: 16000 nM
Beside the measured number, compound 4's estimate is 1.2-fold (0.09 log units) below it; low and high end bracket the measured number.
By their numbers in this assay, from the lowest: compounds 3, 2, 1 and 4 (each within the scatter of the next, the first and the last beyond it).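

In this assay, replacing the 4-fluorophenyl on the carbonyl carbon with 2-methoxyphenyl gives a 1.0-fold higher number from compound 1 to compound 4 (0.02 log units; within the scatter), so the number does not respond to this exchange of one whole aromatic group for another. Among the compounds shown here, the only earlier step on this ring, chloro in place of methyl, gave a 1.7-fold lower number from compound 2 to compound 3 (0.22 log units; within the scatter) on a core without the two methoxy groups; this new step shows a similar lack of a clear shift on the core of compound 1, even though the entering group brings a hydrogen-bond acceptor that the leaving group lacks. Nothing measured here bears on why the number holds steady.

Going by these compounds, both groups are substituted phenyl rings, so the effect of a non-aromatic group at this carbonyl carbon, such as a butyl chain, remains open. Also open, on these data alone, is whether a ring carrying an amine or a carboxylic acid would move the number beyond the scatter.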